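Methoxy in place of hydrogen at the bromo-cleared position

A few compounds are considered here, and "the series" means these few. Any claim that something is new, unique, unknown or untested is made for them only; others in the source may bear on it.

Measured compounds:
compound 1 `Clc1ccc(C2=NN(c3nc(-c4ccc(Br)cc4)cs3)C(c3cccs3)C2)cc1`, 14700 nM
compound 2 `Clc1ccc(C2=NN(c3nc(-c4ccccc4)cs3)C(c3cccs3)C2)cc1`, 190 nM

In a functional assay on MCF7 cells (Homo sapiens) for antiproliferative activity, read by MTT assay, with a stated time of 48 h (a lower number here means a stronger inhibitor, a higher number a weaker inhibitor), compound 2 gives 190 nM and stands lowest of the two numbers; the nearest is compound 1, which gives 14700 nM. Among the compounds with values here, the only step between them is a 77-fold lower number from compound 1 to compound 2 (1.89 log units; beyond the scatter), a large change for a single substituent removed from an aromatic carbon.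

Compound 3 `COc1ccc(-c2csc(N3N=C(c4ccc(Cl)cc4)CC3c3cccs3)n2)cc1` carries the change (methoxy in place of hydrogen on an aromatic carbon), at the same aromatic carbon that held bromo in compound 1 and hydrogen in compound 2. Within the data shown here, the step of a 77-fold lower number from compound 1 to compound 2 (1.89 log units; beyond the scatter) is the one measurement that bears on this position; it shows that a substituent there can push the number up strongly. Whether methoxy behaves like bromo at that carbon is not known from these two compounds, so the direction is uncertain, but the weight of the evidence is toward a higher number. Compound 3 is therefore expected to show a 6.3-fold higher number from compound 2 to compound 3 (0.80 log units; beyond the scatter), an estimated 1200 nM with a range from 150 nM to 10000 nM.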

Compound 3, half-maximal inhibitory concentration: 2480 nM
Compound 3: the middle estimate sits 2.1-fold (0.32 log units) below what was measured; low and high end bracket the measured number.
By their numbers in this assay, from the lowest: compound 2; then compound 3; then compound 1.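

In this assay, phenyl to 4-methoxyphenyl gives a 13-fold higher number from compound 2 to compound 3 (1.12 log units; beyond the scatter) and so shows that the higher number seen at this aromatic carbon is not confined to bromo: both substituents tested so far give a higher number than hydrogen. The two substituents are not equivalent, however, as methoxy in place of bromo gives a 5.9-fold lower number from compound 1 to compound 3 (0.77 log units; beyond the scatter) and the size of the rise therefore depends on the group that enters. Across these three compounds the order at this carbon runs from hydrogen through methoxy to bromo, and no supporting measurement bears on this order.

Going by these compounds, with only two substituents compared with hydrogen, it remains open whether any group at this carbon can match or improve on hydrogen, for example fluoro, an amine, a hydroxyl or a carboxylic acid. On these data alone, the rest of the core is identical in all three compounds, so it is also open whether the same order would hold with methoxy or bromo on another carbon of this ring or with a different group elsewhere on the core.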